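From ethyl to methyl: one small change

The source may report more compounds than this note shows. Statements on the series, on what has been measured and on what is new or still open speak of the compounds shown alone.

Measured in an in vivo ADME assay on the whole organism (strain Sprague-Dawley) for pharmacokinetics, with Rattus norvegicus as the target, at a dose of 5 mg/kg by the oral route; a lower number here means that a smaller share of the oral dose reaches the circulation, a higher number that a larger share of the oral dose reaches the circulation:
Compound 1 `Cc1c(Cl)cc2[nH]c(=O)c(=O)[nH]c2c1N(CC(=O)O)S(C)(=O)=O` gives 7%
Compound 2 `CCc1c(Cl)cc2[nH]c(=O)c(=O)[nH]c2c1N(CCO)S(C)(=O)=O` gives 1%

These two numbers lie within the usual scatter of each other, so compound 2 does not stand apart from compound 1 on this measurement. Compound 3 `Cc1c(Cl)cc2[nH]c(=O)c(=O)[nH]c2c1N(CCO)S(C)(=O)=O` has not yet been measured. It differs from compound 2 in one place. The change hydrogen in place of methyl on a saturated chain carbon bound to an aromatic carbon means hydrogen in place of methyl on a saturated chain carbon bound to an aromatic carbon, so ethyl becomes methyl. Among the compounds with values here, no measured pair shows this change on its own, so the data give no direct guide. With compound 2 at 1% as the starting point, no shift beyond the scatter is expected in either direction. The expected step is a number 2 percentage points higher from compound 2 to compound 3 (within the scatter) and would stay within the scatter. In this assay compound 3 is estimated at 3% within an expected range from 1% to 12% for this small change.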

Compound 3, oral bioavailability in the Rattus norvegicus assay: 4%
Compound 3: middle estimate off by 1 percentage points, on the low side, within the range that was stated.
By their numbers in the Rattus norvegicus assay, from the lowest: compounds 2, 3 and 1 (each within the scatter of the next).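

Ethyl to methyl can now be read on its own for the first time: in the Rattus norvegicus assay compound 2 gives 1% and compound 3 gives 4%, and this change, on a saturated chain carbon bound to an aromatic carbon, gives a number 3 percentage points higher from compound 2 to compound 3 (within the scatter). The second change that can now be read, hydroxymethyl in place of carboxy on a saturated chain carbon bound to a sulfonamide nitrogen, gives in the Rattus norvegicus assay a number 3 percentage points lower from compound 1 to compound 3 (within the scatter). In a physicochemical assay for solubility (on this read-out higher numbers stand for higher solubility and lower numbers for lower solubility), compound 2 gives 72 ug/mL and compound 3 gives 70 ug/mL, and ethyl to methyl gives a 1.0-fold lower number from compound 2 to compound 3 (0.01 log units; within the scatter), so neither change stands out from the scatter in these single comparisons. No supporting measurement is available to explain these numbers.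

Still open, going by these compounds, is whether a longer chain such as propyl at the first place would give a step beyond the scatter. The same question applies to an amine in place of the hydroxymethyl at the second place.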